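Aryl ketone variation in the enone series

The source may hold more compounds than are shown below. What is called first, only, known or untested is meant among the compounds shown, and "the series" means these compounds.

Compound 3 `COc1ccc(-c2cc3ccccc3nc2/C=C/C(=O)c2ccsc2)cc1` gives 6010 nM in a functional assay on MCF7 cells (Homo sapiens) for antiproliferative activity, read by XTT assay, with a stated time of 72 h (on this read-out lower numbers stand for stronger inhibition and higher numbers for weaker inhibition), the second highest of three numbers: compound 1 `COc1ccc(C(=O)/C=C/c2nc3ccccc3cc2-c2ccc(OC)cc2)cc1` gives 7380 nM and compound 2 `COc1ccc(-c2cc3ccccc3nc2/C=C/C(=O)c2ccco2)cc1` gives 710 nM. Within the series, a 1.2-fold lower number from compound 1 to compound 3 (0.09 log units; within the scatter) lies within the scatter, whereas an 8.5-fold higher number from compound 2 to compound 3 (0.93 log units; beyond the scatter) and a 10-fold lower number from compound 1 to compound 2 (1.02 log units; beyond the scatter) lie beyond it. Compound 4 `COc1ccc(-c2cc3ccccc3nc2/C=C/C(=O)c2cnc(N)nc2C)cc1` carries 2-amino-4-methylpyrimidin-5-yl in place of thiophen-3-yl on a carbonyl carbon. Going by the values given here, both earlier swaps on the carbonyl carbon bear on this step; one was flat, the other large, and no measured step covers the entering group, so the direction is open. A number near that of compound 3 is expected for compound 4, with a 1.5-fold lower number from compound 3 to compound 4 (0.18 log units; within the scatter) taken as the most likely size. Compound 4 is estimated at 4000 nM, within 700 nM to 20000 nM.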

Compound 4, half-maximal inhibitory concentration: > 10000 nM
Compound 4 was reported as a limit; the forecaster's own chance of this, stated with the estimate: 10%; middle value at least 2.5-fold (0.39 log units) away from the limit.
By their numbers in this assay, from the lowest: compound 2; then compounds 3 and 1 (each within the scatter of the next). At a limit, above all of these: compound 4.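

Compound 4 stands only as a limit in this assay: the limit of > 10000 nM in this assay, at which 1 of the 4 values shown sits. Against the furan-2-yl ketone, 2-amino-4-methylpyrimidin-5-yl on the carbonyl carbon gives an at least 14-fold higher number from compound 2 to compound 4 (1.14 log units; beyond the scatter), so the low number of that ketone does not extend to this group. Against the other two ketones, an at least 1.6-fold higher number from compound 3 to compound 4 (0.22 log units; that floor lies within the scatter) and an at least 1.3-fold higher number from compound 1 to compound 4 (0.13 log units; that floor lies within the scatter) are floors only, and they leave the order among these three unsettled.

As far as these compounds go, what thiophen-2-yl or furan-3-yl would give here stays open, so ring atom and attachment point remain unseparated. A pyrimidin-5-yl ketone lacking the amine or the methyl would show whether either group matters.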